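Acetyl on the ring amine of compound 2

This account rests on a few compounds, and the source may have more. Where it says the series, first, only, none or still open, it means among the compounds named here.

In an ADME assay on a cell-free system (plasma, Homo sapiens) for metabolic stability, read by LC-MS, with a stated time of 1 h, tested at 10 uM (on this read-out higher numbers stand for a more stable compound and lower numbers for a less stable compound), compound 2 `CC(=O)NCCCC[C@H](NC(=O)[C@@H]1Cc2ccccc2CN1)C(=O)N[C@@H](CCC(=O)C=[N+]=[N-])C(=O)OC(C)C` gives 95%, level with compound 3 `CC(=O)NCCCC[C@H](NC(=O)OC(C)(C)C)C(=O)N[C@@H](CCC(=O)C=[N+]=[N-])C(=O)OC(C)C` at 95%. Compound 1 `CCCCCCCCCCCCCCCC(=O)N[C@@H](CCCCNC(C)=O)C(=O)N[C@@H](CCC(=O)C=[N+]=[N-])C(=O)OC(C)C` gives 84%, a lower number than the other two, by more than the scatter.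

Compound 4 `CC(=O)NCCCC[C@H](NC(=O)[C@@H]1Cc2ccccc2CN1C(C)=O)C(=O)N[C@@H](CCC(=O)C=[N+]=[N-])C(=O)OC(C)C` carries acetyl in place of hydrogen on an amine nitrogen in a ring. For the measured compounds named here, one measured step bears on this change: no change at the digits printed from compound 2 to compound 3 (within the scatter). That step exchanges the whole ring-bearing group on the carbonyl carbon, not just the substituent on the nitrogen, and this assay does not separate the two compounds. Going by the values given here, no measured compound has acetyl on that nitrogen, so the support is indirect. The expected size of the step stays within the scatter, in neither direction with confidence: a number 2 percentage points lower from compound 2 to compound 4 (within the scatter). For compound 4 the estimate is 93%, with an expected range from 84% to 100%.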

Compound 4, percent of the compound remaining: 110%
For compound 4 the middle estimate is 17 percentage points below the measured one; measured number outside the range, above it.
By their numbers in this assay, from the lowest: compound 1; then compounds 2 and 3 (each within the scatter of the next); then compound 4.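

In this assay acetyl in place of hydrogen on the amine nitrogen in the ring gives a number 15 percentage points higher from compound 2 to compound 4 (beyond the scatter) as a direct reading of this position, whereas exchanging the whole group on the carbonyl carbon gave no change at the digits printed from compound 2 to compound 3 (within the scatter) and did not separate the two compounds. Compound 4 at 110% stands above the whole of the starting amount, so the size of the step says little beyond full retention of the compound. Nothing shown accounts for the rise.

As far as these compounds go, whether the rise belongs to acetyl itself or to any group on this nitrogen stays open, and methyl or a longer acyl chain such as propanoyl at the same nitrogen would address that. From the compounds shown here alone, whether acetyl would act the same way on the core of compound 1 or compound 3 also stays open.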